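Carbonyl substituent series: acyclic hydroxy group replaces hydroxypyridyl

A few compounds are considered here, and "the series" means these few. Any claim that something is new, unique, unknown or untested is made for them only; others in the source may bear on it.

Three amides on a shared core have been measured in an assay on cells for positive allosteric modulation of Cystic fibrosis transmembrane conductance regulator variant F508del (Homo sapiens), with stated times of 10 min and 7 s, in the presence of a further agent that is not named here; on this read-out higher numbers stand for an effect only at larger amounts of compound and lower numbers for an effect already at smaller amounts. Compound 1 `CC1(C)Cc2c(sc(NC(=O)c3ccccc3O)c2C(N)=O)C(C)(C)O1` gives 4 nM, compound 2 `CC1(C)Cc2c(sc(NC(=O)c3cccnc3O)c2C(N)=O)C(C)(C)O1` gives 190 nM, and compound 3 `CC1(C)Cc2c(sc(NC(=O)c3cn[nH]c3)c2C(N)=O)C(C)(C)O1` gives 125 nM. Compound 2 holds the highest of the three numbers; its separation from compound 3, a 1.5-fold lower number from compound 2 to compound 3 (0.18 log units; within the scatter), lies within the scatter, whereas the step of a 48-fold higher number from compound 1 to compound 2 (1.68 log units; beyond the scatter) is large and beyond it, as is the parallel step a 31-fold higher number from compound 1 to compound 3 (1.49 log units; beyond the scatter).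

Compound 4 `CC(C)(C)CC(O)C(=O)Nc1sc2c(c1C(N)=O)CC(C)(C)OC2(C)C` is not yet measured. Its difference from compound 2 is a group of 7 heavy atoms (6 carbon, 1 oxygen; no ring) in place of a group of 7 heavy atoms (5 carbon, 1 nitrogen, 1 oxygen; one six-membered aromatic ring with 1 hetero atom), on a carbonyl carbon. Among the measured compounds shown here, no measured step exchanges a ring-bearing group for one without a ring, so the two large steps from compound 1 show only that the group on the carbonyl carbon can move this read-out strongly; they give no direction for this particular exchange. The estimated step is therefore a modest rise in number, a 1.8-fold higher number from compound 2 to compound 4 (0.27 log units; within the scatter), with wide uncertainty. For compound 4 the expected value is 350 nM, within a range from 60 nM to 2000 nM.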

Compound 4, half-maximal effective concentration: 0.54 nM
Estimate against measurement, compound 4: 650-fold (2.81 log units) above, and the stated range ends above it.
By their numbers in this assay, from the lowest: compound 4; then compound 1; then compounds 3 and 2 (each within the scatter of the next).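

In this assay an aromatic ring on the carbonyl carbon proves unnecessary for a low number: the acyclic hydroxy group gives a 350-fold lower number from compound 2 to compound 4 (2.55 log units; beyond the scatter) and a 230-fold lower number from compound 3 to compound 4 (2.36 log units; beyond the scatter). Removing the ring from the 2-hydroxyphenyl amide does not cost activity either, as the change gives a 7.4-fold lower number from compound 1 to compound 4 (0.87 log units; beyond the scatter), a modest step that leaves compound 4 with the lowest number of the set. A hydroxy group alone does not secure a low number, since compound 2 also carries one and stands at 190 nM.

Nothing in the data explains these steps. Going by these compounds, it remains open whether an amine or a methoxy group in place of the hydroxy group of compound 4, or a shorter or longer chain, would keep the number this low.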